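Sulfonamide nitrogen substituents: from compound 2 to compound 3

This account rests on a few compounds, and the source may have more. Where it says the series, first, only, none or still open, it means among the compounds named here.

Compound 2 `Cc1ccc(S(=O)(=O)N(C)C)cc1C#Cc1cc(Cl)ccc1OCC(=O)O` gives 5 nM in an assay on CHO cells for displacement of a labelled ligand from prostaglandin D2 receptor 2 (Homo sapiens), read by scintillation counting; a lower number here means a stronger inhibitor, a higher number a weaker inhibitor. Compound 1 `Cc1ccc(S(=O)(=O)N(C)CCN(C)C)cc1C#Cc1cc(Cl)ccc1OCC(=O)O` gives 369 nM in this assay. For the measured compounds named here, of the two numbers so far, compound 2 stands lowest; its nearest neighbour is compound 1, and the only measured step, a 74-fold lower number from compound 1 to compound 2 (1.87 log units; beyond the scatter), goes with hydrogen in place of (dimethylamino)methyl on a saturated chain carbon bound to a sulfonamide nitrogen.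

Compound 3 `Cc1ccc(S(=O)(=O)N(C)C(C)C)cc1C#Cc1cc(Cl)ccc1OCC(=O)O` is not yet measured. It differs from compound 2 by isopropyl in place of methyl on a sulfonamide nitrogen. Going by the values given here, the one measured step bears on the same sulfonamide nitrogen, but it tracks removal of a (dimethylamino)methyl group from a chain carbon, not exchange of one alkyl group for another directly on the nitrogen; it therefore bears on the present change only loosely. Among the compounds with values here, no measured step tells how a larger alkyl group on that nitrogen alone behaves. A step within or just beyond the scatter is expected in this assay, if anything towards a somewhat higher number. Compound 3 is expected at 10 nM, with a range of 3 nM to 40 nM. The expected step is a 2.0-fold higher number from compound 2 to compound 3 (0.30 log units; within the scatter).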

Compound 3, inhibition constant: 3.8 nM
For compound 3 the middle estimate is 2.6-fold (0.42 log units) above the measured one; low and high end bracket the measured number.
By their numbers in this assay, from the lowest: compounds 3 and 2 (each within the scatter of the next); then compound 1.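

On the sulfonamide nitrogen, in this assay, the exchange of methyl for isopropyl gives a 1.3-fold lower number from compound 2 to compound 3 (0.12 log units; within the scatter) and so leaves the number in the same range, which shows that this nitrogen accepts an alkyl group larger than methyl with no step beyond the scatter. The high number of compound 1 therefore does not extend to every group larger than methyl: the second comparison gives a 97-fold lower number from compound 1 to compound 3 (1.99 log units; beyond the scatter) and stands close to the earlier 74-fold lower number from compound 1 to compound 2 (1.87 log units; beyond the scatter), so that among these three compounds only the one with 2-(dimethylamino)ethyl on this nitrogen sits apart, with methyl and isopropyl reading alike. No supporting measurement is available to explain either step.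

Still open, as far as these compounds go, is whether the high number of compound 1 goes with the length of the chain or with its terminal amine, a question that a butyl chain or a 2-methoxyethyl group on this nitrogen would address. Also open, from the compounds shown here alone, is how far the tolerance reaches, for instance with a cyclohexyl or benzyl group on the nitrogen, or with a plain hydrogen in place of methyl.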